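Swapping tert-butyl in compound 2: notes on compound 3

The source may hold more compounds than are shown below. What is called first, only, known or untested is meant among the compounds shown, and "the series" means these compounds.

Measured in a physicochemical assay for solubility, in phosphate buffer, at pH 6.5; a higher number here means a more soluble compound, a lower number a less soluble compound:
- compound 1 `CC(C)(C)c1ccccc1Oc1ncccc1NC(=O)Nc1ccc(N2CCCCC2)cc1`: 9 ug/mL
- compound 2 `CN(C)CC(C)(C)COc1ccc(NC(=O)Nc2cccnc2Oc2ccccc2C(C)(C)C)cc1`: 103 ug/mL

Of these two numbers, compound 2 holds the higher, at 103 ug/mL, and its gap to compound 1 lies beyond the scatter. Compound 3 `CN(C)CC(C)(C)COc1ccc(NC(=O)Nc2cccnc2Oc2ccccc2[Si](C)(C)C)cc1` differs from compound 2 in one place: a group of 4 heavy atoms (3 carbon, 1 silicon; no ring) in place of a group of 4 heavy atoms (4 carbon; no ring), on an aromatic carbon. The tert-butyl group leaves, and the entering group sits on an aromatic carbon of a six-membered aromatic ring of carbon only, ortho to a large group.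

Among the measured compounds shown here, the only measured step is an 11-fold higher number from compound 1 to compound 2 (1.06 log units; beyond the scatter). This large step replaced piperidin-1-yl with 2-((dimethylamino)methyl)-2-methylpropoxy, so it sets no size for a change at the tert-butyl group. For the measured compounds named here, no measured step covers that group, and the data offer only indirect guidance. No step beyond the scatter is expected in this assay, and no firm direction is expected. The expected step is a 1.1-fold lower number from compound 2 to compound 3 (0.06 log units; within the scatter). For compound 3 the estimated value is 90 ug/mL, with an expected range of 40 ug/mL to 190 ug/mL.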

Compound 3, solubility: 173 ug/mL
Estimate against measurement, compound 3: 1.9-fold (0.28 log units) below; the measured number falls inside the stated range.
By their numbers in this assay, from the lowest: compound 1; then compounds 2 and 3 (each within the scatter of the next).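

Position notes: in this assay, the first measured exchange at the tert-butyl position, a group of 3 carbon and 1 silicon in place of 4 carbon, gives a 1.7-fold higher number from compound 2 to compound 3 (0.23 log units; within the scatter), so the two compounds are not separated by this read-out. Among the compounds shown here, this position, on an aromatic carbon ortho to a large group, therefore accepts this exchange of one carbon for silicon without a step beyond the scatter, whereas the earlier compounds covered only the change at the other substituent, an 11-fold higher number from compound 1 to compound 2 (1.06 log units; beyond the scatter), and said nothing about this place. No supporting data bear on why the number for compound 3 falls where it does.

Still open, from the compounds shown here alone, is whether a group that differs more from tert-butyl at this position, such as a trifluoromethyl, a primary amine or a carboxylic acid, would give a step beyond the scatter. The compounds shown also leave open whether the same silicon-for-carbon exchange would stay within the scatter with piperidin-1-yl in place of the 2-((dimethylamino)methyl)-2-methylpropoxy group.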